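A few compounds are considered here, and "the series" means these few. Any claim that something is new, unique, unknown or untested is made for them only; others in the source may bear on it.

Compound 1 (`Cc1cc(C)c2cc(C(=O)NC3CCCCC3)[nH]c2c1`), compound 2 (`Cc1cc(C)c2cc(C(=O)Nc3ccncc3)[nH]c2c1`) and compound 3 (`Cc1cc(C)c2cc(C(=O)NC3CC3)[nH]c2c1`) share one core and differ in the group on an amide-type nitrogen. In an ADME assay on Vero cells (Chlorocebus sabaeus) for cytotoxicity, read by resazurin assay (a higher number here means a weaker inhibitor, a lower number a stronger inhibitor), compound 1 gives > 200000 nM, and this is a limit of the assay, not a number. The entry for compound 2 reads "not determined" (no result reported), and the entry for compound 3 reads "not determined" (no result reported). Compound 3 therefore offers no number of its own to start from.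

The next compound is compound 4 (`Cc1cc(C)c2cc(C(=O)NCC3CCCCC3)[nH]c2c1`), and the change is cyclohexylmethyl in place of cyclopropyl on an amide-type nitrogen. Going by the values given here, no measured step shows what a swap of this kind does in this assay, so any expectation here is a rough one. Among the compounds with values here, the only guide is compound 1 at > 200000 nM, again a limit. A modest move towards a lower number is expected, or none beyond the scatter, and the assay may well report only a limit again. For compound 4 the estimated value is 150000 nM, with an expected range from 50000 nM to 300000 nM.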

Compound 4, half-maximal inhibitory concentration: > 200000 nM
Compound 4 gave a limit, no number (the forecaster's own chance of this, stated with the estimate: 60%); middle value at least 1.3-fold (0.12 log units) from the limit.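

Going by these compounds alone, compound 1 and compound 4 each give a limit rather than a number, so no step between them can be read, and both sit at the same value: the limit of > 200000 nM in this assay, at which 2 of the 4 values shown sit. The compounds shown leave open whether changing the group on the amide-type nitrogen shifts the result in this assay at all.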